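The source may hold more compounds than are shown below. What is called first, only, known or untested is meant among the compounds shown, and "the series" means these compounds.

Three compounds have been measured in a functional assay on the whole organism with Mus musculus as the target, in the maximal electroshock model, at a dose of 50 mg/kg by the oral route; on this read-out lower numbers stand for less inhibition and higher numbers for more inhibition at the one dose given (going by the name of the read-out):

Compound 1, `CN(C)CCCOc1ccccc1/C=C/c1ccccc1`, gives 14.2%.
Compound 2, `CN(C)CCCCOc1ccccc1/C=C/c1cccc(Cl)c1`, gives 14.3%.
Compound 3, `CN(C)CCCCOc1ccccc1/C=C/c1ccc(Cl)cc1`, gives 0%.

Compound 1 stands second highest of these three numbers. Its nearest neighbour is compound 2, whose value lies within the usual scatter of it, so the two cannot be told apart; compound 3 lies below compound 1 by more than the scatter. Within the data shown here, the one step between compounds that differ in a single place, a number 14.3 percentage points lower from compound 2 to compound 3 (beyond the scatter), concerns the chlorophenyl group and says nothing about the amine end of the chain.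

Compound 4, `C(=C/c1ccccc1OCCCCN1CCCC1)\c1ccccc1`, has not yet been measured in this assay. It differs from compound 1 in one place: (pyrrolidin-1-yl)methyl in place of dimethylamino on a saturated chain carbon, three bonds along the chain from an oxygen on an aromatic ring. Among the measured compounds shown here, no measured pair isolates this change, so the only guide is the value of compound 1 itself. With nothing to suggest a shift in either direction, the expected step of a number 0.2 percentage points lower from compound 1 to compound 4 (within the scatter) is estimated to lie within the scatter. Compound 4 is therefore estimated at 14%, with an expected range from 0% to 30%.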

Compound 4, a percentage reported as inhibition, in the whole organism at one dose (the size of the read-out at that dose, not a potency): 42.9%
The estimate for compound 4 lay 28.9 percentage points below the measured number, and the stated range ends below it.
By their numbers in this assay, from the lowest: compound 3; then compounds 1 and 2 (each within the scatter of the next); then compound 4.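

Replacing dimethylamino with (pyrrolidin-1-yl)methyl on this saturated chain carbon gives, in this assay, a number 28.7 percentage points higher from compound 1 to compound 4 (beyond the scatter). Among these compounds, the only earlier step concerned the chlorophenyl group, so this is the first sign that the read-out also responds to a change at the amine end of the chain. No measurement shown gives a reason for this step.

The change brings in a five-membered ring and the extra methyl carbon together, so the compounds shown cannot say which of the two carries the difference, or whether both are needed. From the compounds shown here alone, how a six-membered cyclic amine such as piperidine or morpholine would read at this place also stays open.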